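The source may hold more compounds than are shown below. What is called first, only, known or untested is meant among the compounds shown, and "the series" means these compounds.

Compound 3 `CCCCNc1nc(N)nc(C)c1C#C[Si](C)(C)C` gives 9240 nM in an assay on HEK293 cells for agonist activity at Toll-like receptor 8 (Homo sapiens), read by spectrophotometry (a lower number here means that less compound is needed, a higher number that more compound is needed for the effect), the highest number among the three measured compounds; compound 1 `CCCCNc1nc(N)nc(C)c1CCCCO` gives 1310 nM and compound 2 `CCCCNc1nc(N)nc(C)c1CCCC(C)(C)O` gives 1220 nM. Compound 4 `CCCCNc1nc(N)nc(C)c1C` carries one carbon atom in place of a group of 6 heavy atoms (5 carbon, 1 silicon; no ring), on an aromatic carbon. Among the compounds with values here, two measured steps bear on this move. a 1.1-fold lower number from compound 1 to compound 2 (0.03 log units; within the scatter) shows that the hydroxymethyl-to-1-hydroxy-1-methylethyl change hardly registers, whereas a 7.1-fold higher number from compound 1 to compound 3 (0.85 log units; beyond the scatter) shows that replacing the hydroxybutyl chain with the silicon-bearing group raises the number modestly. Compound 4 removes that group again but does not restore the chain, so a fall in this assay back toward compound 1 is expected, though not all the way; the expected step is a 3.1-fold lower number from compound 3 to compound 4 (0.49 log units; beyond the scatter). Compound 4 is accordingly estimated at 3000 nM, within a range of 800 nM to 12000 nM.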

Compound 4, half-maximal effective concentration: 3280 nM
Compound 4: middle estimate off by 1.1-fold (0.04 log units), on the low side, within the range that was stated.
By their numbers in this assay, from the lowest: compounds 2 and 1 (each within the scatter of the next); then compound 4; then compound 3.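

In this assay, methyl at this aromatic carbon gives a 2.8-fold lower number from compound 3 to compound 4 (0.45 log units; beyond the scatter) on replacing the silicon-bearing group with its triple bond, yet it does not match the hydroxylated chains, with a 2.5-fold higher number from compound 1 to compound 4 (0.40 log units; beyond the scatter) and a 2.7-fold higher number from compound 2 to compound 4 (0.43 log units; beyond the scatter) as the steps. Relative to methyl, the number at this position therefore moves in both directions: it is lower with the chains of compound 1 and compound 2 and higher with the silicon-bearing group of compound 3. Nothing measured here accounts for either direction. Still open, as far as these compounds go, is whether the chain or its hydroxyl carries the difference from methyl, a question that a plain butyl chain or a terminal amine at this carbon would address.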